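The source may hold more compounds than are shown below. What is called first, only, known or untested is meant among the compounds shown, and "the series" means these compounds.

In a functional assay on the whole organism (strain albino) with Mus musculus as the target, with a stated time of 0.5 h (a higher number here means that more compound is needed for the effect, a lower number that less compound is needed), compound 3 (`CC(=O)N1N=C(Nc2nc3ccc(C)cc3s2)CC1c1ccc(Cl)cc1`) gives 27.5 umol/kg, the lower of the two numbers available. Compound 1 (`COc1ccc(C2CC(Nc3nc4ccc(Cl)cc4s3)=NN2C(C)=O)cc1O`) gives 132 umol/kg, and for compound 2 (`CC(=O)N1N=C(Nc2nc3ccc(C)cc3s2)CC1OC1=CC=C1`) the entry reads "not determined" (no result reported). Compound 4 (`CC(=O)N1N=C(Nc2nc3ccc(Cl)cc3s2)CC1c1ccc(Cl)cc1`) carries chloro in place of methyl on an aromatic carbon of compound 3: chloro in place of methyl on an aromatic carbon. Among the measured compounds shown here, no measured pair isolates this exchange, so the expectation rests on compound 3 at 27.5 umol/kg and on the structural change alone. No shift beyond the usual scatter is expected in this assay, and the estimated change is a 1.1-fold higher number from compound 3 to compound 4 (0.04 log units; within the scatter). For compound 4 the expected value is 30 umol/kg, within an estimated range of 12 umol/kg to 75 umol/kg.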

Compound 4, dose for half-maximal effect: 81.5 umol/kg
Beside the measured number, compound 4's estimate is 2.7-fold (0.43 log units) below it; the measured number lies above the stated range.
By their numbers in this assay, from the lowest: compound 3; then compounds 4 and 1 (each within the scatter of the next).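

In this assay, this position on the six-membered aromatic ring of the fused system is sensitive to the exchange: chloro in place of methyl gives a 3.0-fold higher number from compound 3 to compound 4 (0.47 log units; beyond the scatter). With chloro held at that position, 4-chlorophenyl in place of 3-hydroxy-4-methoxyphenyl on a saturated ring carbon gives a 1.6-fold lower number from compound 1 to compound 4 (0.21 log units; within the scatter), so this second exchange shows no shift beyond the scatter. Nothing at hand accounts for either step.

Still open, as far as these compounds go, is how fluoro, an amine or a carboxylic acid at this aromatic carbon would compare with methyl and chloro. Also open, from the compounds shown here alone, is whether the 3-hydroxy-4-methoxyphenyl exchange would read the same with methyl at that carbon.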